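This account rests on a few compounds, and the source may have more. Where it says the series, first, only, none or still open, it means among the compounds named here.

Of the compounds shown here, three have so far been tested in a toxicity assay on THP-1 cells (Homo sapiens) for inhibition; a lower number here means that less compound is tolerated, a higher number that more compound is tolerated. Compound 2 `COc1ccc(-c2cnc(NC(=O)C3CCCCC3)n2C)cc1` reaches only the limit of the assay, > 100000 nM. Compound 1 `COc1ccc(-c2cnc(NC(=O)c3ncc[nH]3)n2C)cc1` likewise stops at a limit, > 100000 nM. Compound 3 `Cn1c(-c2ccccc2)cnc1NC(=O)C1CCCCC1` also stops at a limit, > 100000 nM. Because all three values sit at the limit of > 100000 nM in this assay, at which 3 of the 3 values shown sit, the step that the two limits leave unreadable from compound 2 to compound 1 and the step that the two limits leave unreadable from compound 2 to compound 3 cannot be given a size. The core of compound 3 differs from the core of compound 2 by hydrogen in place of methoxy on an aromatic carbon. Among the compounds with values here, compound 4 `Cn1c(-c2ccccc2)cnc1NC(=O)c1ncc[nH]1` has not yet been measured; it differs from compound 3 by 1H-imidazol-2-yl in place of cyclohexyl on a carbonyl carbon, which is the same change, at the same place, as the one from compound 2 to compound 1, (1H-imidazol-2-yl in place of cyclohexyl on a carbonyl carbon). Because the step that the two limits leave unreadable from compound 2 to compound 1 ended at the limit of > 100000 nM in this assay, at which 3 of the 3 values shown sit, the step that the limit leaves unreadable from compound 3 to compound 4 is expected to be flat. Compound 4 is therefore estimated to give about 150000 nM in this assay.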

Compound 4, half-maximal cytotoxic concentration: > 100000 nM
Compound 4: no number, only a limit; the forecaster's own chance of this, stated with the estimate: 85%; the middle value lies beyond the limit too.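

Compound 4 also stops at a limit, so the steps to it from compound 3 and compound 1 cannot be read: the limit of > 100000 nM in this assay, at which 4 of the 4 values shown sit.

The compounds shown leave open what concentration harms these cells, and whether either change affects it.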